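Methyl to hydrogen in a series with one number

The compounds below may be only part of what the source reports. "The series", "measured", "known", "first", "only" and "open" are said of these compounds alone.

Among the compounds with values here, in a functional assay on PC-3M cells (Homo sapiens) for inhibition, read by sulforhodamine B assay (on this read-out higher numbers stand for weaker inhibition and lower numbers for stronger inhibition), compound 1 (`NC(c1ccc(Cl)cc1)C1CCN(c2ccnc3[nH]ccc23)CC1`) gives 5300 nM, the only number so far. For compound 2 (`Cc1nc2c(N3CCC(N)CC3)ncnc2[nH]1`) the entry is "not determined" (no result reported), so compound 2 has no place on the scale. The next structure is compound 3 (`NC1CCN(c2ncnc3[nH]cnc23)CC1`). The change, (hydrogen in place of methyl on an aromatic carbon), is hydrogen in place of methyl on an aromatic carbon. Within the data shown here, no measured step covers this change, so any size is a judgement: in this assay no shift beyond the scatter is expected from it, and inhibition weaker than that of compound 1 at 5300 nM is expected. For compound 3 the estimated value is 30000 nM, with an expected range from 8000 nM to 100000 nM.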

Compound 3, half-maximal inhibitory concentration: > 50000 nM
Compound 3: a limit, no number; the forecaster's own chance of this, stated with the estimate: 35%; at least 1.6-fold (0.22 log units) between middle value and limit.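

No step can be read between compound 2, which has no number, and compound 3. Compound 3 gives > 50000 nM, a limit and not a number. From the compounds shown here alone, the size of any effect of hydrogen in place of methyl in this assay stays open.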